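Bromo gives way to methyl on the shared core

The source may report more compounds than this note shows. Statements on the series, on what has been measured and on what is new or still open speak of the compounds shown alone.

In an ADME assay on HEK-293T cells (Homo sapiens) for cytotoxicity, read by luminescence, with a stated time of 24 h (a lower number here means that less compound is tolerated, a higher number that more compound is tolerated), compound 1 (`COc1ccc(Cn2c(C(=O)N3CCC(C(N)=O)CC3)cc3sccc32)cc1`) gives > 100000 nM as a limit of the assay, not a number. Compound 2 (`CCCNC(=O)C1CCN(C(=O)c2cc3sc(Br)cc3n2Cc2ccc(OC)cc2)CC1`) gives > 100000 nM as a limit too. Both stand at the limit of > 100000 nM in this assay, at which 2 of the 2 values shown sit, in the data so far. Compound 3 (`CCCNC(=O)C1CCN(C(=O)c2cc3sc(C)cc3n2Cc2ccc(OC)cc2)CC1`) has methyl in place of bromo on an aromatic carbon next to the ring sulfur (methyl in place of bromo on an aromatic carbon). Among the measured compounds shown here, no measured step bears on this change, and no step beyond the scatter is expected in this assay in either direction. The expected change is a number no higher from compound 2 to compound 3 (the limit leaves the size open) in this estimate. Compound 3 is expected at 100000 nM for the half-maximal cytotoxic concentration, with an estimated range from 40000 nM to 100000 nM around it.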

Compound 3, half-maximal cytotoxic concentration: 36300 nM
Estimate against measurement, compound 3: 2.8-fold (0.44 log units) above; measured number outside the range, below it.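

In this assay, methyl in place of bromo on an aromatic carbon next to the ring sulfur gives an at least 2.7-fold lower number from compound 2 to compound 3 (0.44 log units; beyond the scatter), so a change at this position can move the read-out on the shared core. Compound 3 is the first compound here with a number rather than a limit, and the full size of the step stays open: the limit of > 100000 nM in this assay, at which 2 of the 3 values shown sit.

The compounds shown leave open how an amine, a carboxylic acid or a longer chain at this position would read in this assay.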